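A few compounds are considered here, and "the series" means these few. Any claim that something is new, unique, unknown or untested is made for them only; others in the source may bear on it.

Of the compounds shown here, three sharing one core have been measured in a functional assay on HT-29 cells (Homo sapiens) for cytotoxicity, read by MTT assay, with a stated time of 24 h, tested at 80 ug/mL; a lower number here means a weaker effect, a higher number a stronger effect of the compound at the concentration tested. Compound 1 `Cn1c(-c2ccc(NC(=O)CSc3nc4ccccc4o3)cc2)nc(-c2ccccc2)c1-c1ccccc1` gives 81.5%. Compound 2 `Cn1cnnc1SCC(=O)Nc1ccc(-c2nc(-c3ccccc3)c(-c3ccccc3)n2C)cc1` gives 88%. Compound 3 `Cn1c(-c2ccc(NC(=O)CSC3=NCCS3)cc2)nc(-c2ccccc2)c1-c1ccccc1` gives 75.2%, the lowest of the three numbers, although a number 6.3 percentage points lower from compound 1 to compound 3 (within the scatter) and only a number 12.8 percentage points lower from compound 2 to compound 3 (beyond the scatter). Compound 4 `CN1CCN(CC(=O)Nc2ccc(-c3nc(-c4ccccc4)c(-c4ccccc4)n3C)cc2)CC1` has not been measured. Relative to compound 3 it carries a group of 7 heavy atoms (5 carbon, 2 nitrogen; one six-membered non-aromatic ring with 2 hetero atoms) in place of a group of 6 heavy atoms (3 carbon, 1 nitrogen, 2 sulfur; one five-membered non-aromatic ring with 2 hetero atoms), on a saturated chain carbon bound to a carbonyl carbon. Within the data shown here, none of the measured steps touches this place: a number 6.5 percentage points higher from compound 1 to compound 2 (within the scatter), a number 6.3 percentage points lower from compound 1 to compound 3 (within the scatter) and a number 12.8 percentage points lower from compound 2 to compound 3 (beyond the scatter) all swap the group on the sulfur, and every one of them stayed small. With that ring gone altogether, the guidance is weak, so for compound 4 a step of a number 1.2 percentage points lower from compound 3 to compound 4 (within the scatter) is expected. The value of compound 4 is estimated at 74%, between 52% and 90%.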

Compound 4, a percentage reported as activity, at one concentration (the size of the read-out at that concentration, not a potency): 53.1%
Beside the measured number, compound 4's estimate is 20.9 percentage points above it, and the stated range covers the measured number.
By their numbers in this assay, from the lowest: compound 4; then compounds 3, 1 and 2 (each within the scatter of the next, the first and the last beyond it).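

Every earlier step swapped only the group on the sulfur, whereas compound 4 has no such sulfur and carries 4-methylpiperazin-1-yl directly on the saturated chain carbon bound to a carbonyl carbon. In this assay this change gives a number 22.1 percentage points lower from compound 3 to compound 4 (beyond the scatter) and a number 34.9 percentage points lower from compound 2 to compound 4 (beyond the scatter) and also a number 28.4 percentage points lower from compound 1 to compound 4 (beyond the scatter), so the read-out does respond to a change at this place. Nothing available here explains the lower number. Still open, going by these compounds, is whether losing the sulfur or gaining the 4-methylpiperazin-1-yl group accounts for it. A morpholine ring or a diethylamine on the same carbon would test the ring's part in this.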